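The source may report more compounds than this note shows. Statements on the series, on what has been measured and on what is new or still open speak of the compounds shown alone.

Three measured compounds share one core and differ only in the group on a saturated chain carbon bound to an amide-type nitrogen. Compound 1, `COc1ccc(CNC(=O)c2nc(C(C)(C)NC(=O)OCc3ccccc3)nc(O)c2O)cc1`, carries a 4-methoxyphenyl there and in an ADME assay on C8166 cells (Homo sapiens) for cytotoxicity, read by MTT assay, with a stated time of 3 days (on this read-out lower numbers stand for higher toxicity in this test and higher numbers for lower toxicity in this test), compound 1 gives 164000 nM. Compound 2, `COCCNC(=O)c1nc(C(C)(C)NC(=O)OCc2ccccc2)nc(O)c1O`, carries a methoxymethyl; in this assay compound 2 gives 348000 nM. Compound 3, `CC(C)(NC(=O)OCc1ccccc1)c1nc(O)c(O)c(C(=O)NCc2ccc(C(F)(F)F)cc2)n1`, carries a 4-(trifluoromethyl)phenyl and in this assay compound 3 gives 58100 nM, the lowest of the three numbers: its nearest neighbour is compound 1 and its furthest is compound 2, with a 6.0-fold lower number from compound 2 to compound 3 (0.78 log units; beyond the scatter).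

Compound 4, `CC(C)(NC(=O)OCc1ccccc1)c1nc(O)c(O)c(C(=O)NCc2ccccc2Cl)n1`, keeps everything else and differs from compound 3 only in the change (2-chlorophenyl in place of 4-(trifluoromethyl)phenyl on a saturated chain carbon bound to an amide-type nitrogen). Within the data shown here, two measured steps bear on this change, since both end at the group that leaves: a 2.8-fold lower number from compound 1 to compound 3 (0.45 log units; beyond the scatter) and a 6.0-fold lower number from compound 2 to compound 3 (0.78 log units; beyond the scatter). Both place the 4-(trifluoromethyl)phenyl of compound 3 at the low end of what has been seen, so a group that replaces it is expected to give a higher number, in the direction of compound 1, though a ring remains and the shift is expected to stay modest. The step from compound 3 to compound 4 is therefore estimated at a 1.6-fold higher number from compound 3 to compound 4 (0.21 log units; within the scatter). For compound 4 the expected value in this assay is 95000 nM, estimated to lie between 40000 nM and 220000 nM.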

Compound 4, half-maximal cytotoxic concentration: 53900 nM
For compound 4 the middle estimate is 1.8-fold (0.25 log units) above the measured one; low and high end bracket the measured number.
By their numbers in this assay, from the lowest: compounds 4 and 3 (each within the scatter of the next); then compound 1; then compound 2.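

In this assay the 2-chlorophenyl and the 4-(trifluoromethyl)phenyl cannot be told apart on this saturated chain carbon bound to an amide-type nitrogen (a 1.1-fold lower number from compound 3 to compound 4 (0.03 log units; within the scatter)), so the low end of the series is no longer held by compound 3 alone. The 2-chlorophenyl also repeats the gaps already seen for the 4-(trifluoromethyl)phenyl, with a 6.5-fold lower number from compound 2 to compound 4 (0.81 log units; beyond the scatter) and a 3.0-fold lower number from compound 1 to compound 4 (0.48 log units; beyond the scatter) both beyond the scatter, which gives two different substituted phenyl groups at the low end, although compound 1 shows that a ring here does not by itself give so low a number. Nothing available explains why these two groups fall together or why the 4-methoxyphenyl stands apart from them.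

The compounds shown leave open whether the number follows the chlorine itself or where it sits, which a 4-chlorophenyl would address. They also leave open how an unsubstituted phenyl, a longer chain or a carboxylic acid at this position would compare in this assay with the groups seen so far.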